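Methylating the phenol on the dimethoxyphenyl analogue

The source may report more compounds than this note shows. Statements on the series, on what has been measured and on what is new or still open speak of the compounds shown alone.

Two compounds of the series have numbers in a functional assay on HCT-15 cells (Homo sapiens) for cytotoxicity, read by CCK-8 assay and cell counting, with a stated time of 72 h (on this read-out lower numbers stand for stronger inhibition and higher numbers for weaker inhibition), so far. Compound 1 `COc1ccc(-c2cc3ccccc3c(-c3cccc(O)c3)n2)cc1` gives 1200 nM in this assay. Compound 2 `COc1cc(OC)cc(-c2cc3ccccc3c(-c3cccc(O)c3)n2)c1` gives 840 nM in this assay, the lower of the two numbers, but the gap to compound 1 lies within the usual scatter, so the two cannot be ordered on these data. Compound 3 `COc1cc(OC)cc(-c2cc3ccccc3c(-c3cccc(OC)c3)n2)c1` is the next member; it differs from compound 2 by methyl in place of hydrogen on an oxygen on an aromatic ring. Within the data shown here, no measured pair shows this change, so there is nothing in the data to set its size or direction; the working expectation is a step in this assay no larger than the scatter, or a modest move toward weaker inhibition. On that basis compound 3 is expected to give 1200 nM in this assay, with a range of 400 nM to 3600 nM. The step this implies, a 1.4-fold higher number from compound 2 to compound 3 (0.15 log units; within the scatter), is an estimate and not a measurement.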

Compound 3, half-maximal inhibitory concentration: 1170 nM
Compound 3: the middle estimate sits 1.0-fold (0.01 log units) above what was measured, within the range that was stated.
By their numbers in this assay, from the lowest: compounds 2, 3 and 1 (each within the scatter of the next).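

In this assay the series now has its first measured step at this position, and a 1.4-fold higher number from compound 2 to compound 3 (0.14 log units; within the scatter) shows that replacing the hydroxy with methoxy on the 3-hydroxyphenyl group does not separate the two compounds. The free hydroxy hydrogen is therefore not required to keep compound 3 within the scatter of compound 2, although this rests on a single pair with the dimethoxyphenyl group in place. Nothing in the data gives a reason for this outcome.

Still open, going by these compounds, is whether a longer chain on that oxygen, such as ethoxy, or an amine in place of the hydroxy would produce a step beyond the scatter. On these data alone, it is also open whether the same methyl-for-hydrogen change behaves alike on the core of compound 1.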